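A few compounds are considered here, and "the series" means these few. Any claim that something is new, unique, unknown or untested is made for them only; others in the source may bear on it.

Measured compounds:
compound 1 `Cc1cc(NC(=O)c2cccc(C(F)(F)F)c2)ccc1NS(=O)(=O)C(F)(F)F` — 131000 nM
compound 2 `Cc1cc(NC(=O)c2cc(C(F)(F)F)cc(C(F)(F)F)c2)ccc1NS(=O)(=O)C(F)(F)F` — 182000 nM
compound 3 `CCS(=O)(=O)Nc1ccc(NC(=O)c2cccc(C(F)(F)F)c2)cc1Cl` — 159000 nM

In an ADME assay on HEK293 cells (Homo sapiens) for cytotoxicity, read by MTT assay, with a stated time of 48 h (on this read-out higher numbers stand for weaker inhibition and lower numbers for stronger inhibition), these three compounds give numbers that lie close together. Compound 1 differs from compound 2 by trifluoromethyl in place of hydrogen on an aromatic carbon, and the step this made was a 1.4-fold higher number from compound 1 to compound 2 (0.14 log units; within the scatter). The difference between the core of compound 1 and the core of compound 3 is not broken down here. Compound 3 itself gives 159000 nM in this assay, and its distance from compound 1 and from compound 2 is each within the usual scatter.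

Compound 4 `CCS(=O)(=O)Nc1ccc(NC(=O)c2cc(C(F)(F)F)cc(C(F)(F)F)c2)cc1Cl` is not yet measured. It differs from compound 3 by trifluoromethyl in place of hydrogen on an aromatic carbon, the same change seen from compound 1 to compound 2: the place lines of the two changes agree word for word. Since the earlier step, a 1.4-fold higher number from compound 1 to compound 2 (0.14 log units; within the scatter), stayed within the scatter, the step from compound 3 to compound 4 is expected to be a 1.3-fold higher number from compound 3 to compound 4 (0.10 log units; within the scatter). For compound 4 the estimated value in this assay is 200000 nM, with a likely range from 120000 nM to 350000 nM.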

Compound 4, half-maximal inhibitory concentration: 32200 nM
For compound 4 the middle estimate is 6.2-fold (0.79 log units) above the measured one; measured number below the stated range.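

In this assay, trifluoromethyl in place of hydrogen on an aromatic carbon gave a 4.9-fold lower number from compound 3 to compound 4 (0.69 log units; beyond the scatter), so the change did not carry over from one core to the other: the same change on two cores in this assay, a 1.4-fold higher number (0.14 log units; within the scatter) from compound 1 to compound 2 and a 4.9-fold lower number (0.69 log units; beyond the scatter) from compound 3 to compound 4, 6.9-fold (0.84 log units) apart, beyond the scatter of two such steps

The step on the core of compound 1 is therefore no reliable guide to the same change on the core of compound 3 in this series. It does not show which part of the difference between the two cores lies behind the gap, and one pair on each core says nothing about how the change would behave on any further core.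

The compounds shown leave open whether the chlorine on the core of compound 3 or the ethyl group on its sulfonyl accounts for the gap, a question that a core carrying only one of these could settle. They also leave open whether a nitrile or an amine in place of the added trifluoromethyl would separate the two cores in the same way.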